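Quaternary ammonium butyrates: cyclopropyl for propyl on nitrogen

The compounds below may be only part of what the source reports. "The series", "measured", "known", "first", "only" and "open" are said of these compounds alone.

Measured so far:
compound 1, `CC[N+](C)(CC)CCCC(=O)[O-]`: in an assay for inhibition of gamma-butyrobetaine dioxygenase (Homo sapiens), read by HPLC, with stated times of 15 min and 30 min (on this read-out lower numbers stand for stronger inhibition and higher numbers for weaker inhibition), compound 1 gives 100000 nM.
compound 2, `CCCC[N+](C)(C)CCCC(=O)[O-]`: in this assay compound 2 returns only a limit, > 1000000 nM.
compound 3, `C[N+](C)(CCCC(=O)[O-])Cc1ccccc1`: in this assay compound 3 likewise returns only a limit, > 1000000 nM.

Going by the values given here, compound 2 thus stands at the edge of what this assay reports, with no number of its own; the limit of > 1000000 nM in this assay, at which 2 of the 3 values shown sit, marks where two of the three values in the set sit, and compound 1 is the only member with a measured number. Nothing in the set separates compound 2 from compound 3, as both are limits.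

Compound 4, `C[N+](C)(CCCC(=O)[O-])CC1CC1`, differs from compound 2 in one place: cyclopropyl in place of propyl on a saturated chain carbon bound to an amine nitrogen; cut one bond further out, the same change reads butyl to cyclopropylmethyl. Among the compounds with values here, no step between measured compounds matches this change, and the starting point is a limit rather than a number, so no direction can be read from the set. The step from compound 2 to compound 4 in this assay is expected to be an at least 1.2-fold lower number from compound 2 to compound 4 (0.09 log units; that floor lies within the scatter), which is no more than the usual scatter. Compound 4 is expected to give about 800000 nM in this assay, between 200000 nM and 3000000 nM, with a real chance that only a limit is returned again.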

Compound 4, half-maximal inhibitory concentration: > 1000000 nM
Compound 4 was reported as a limit (the forecaster's own chance of this, stated with the estimate: 60%); middle value at least 1.2-fold (0.09 log units) away from the limit.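

In this assay compound 4 gives > 1000000 nM and this is only a limit. Compound 2 likewise returns only a limit, so no step can be read between compound 2 and compound 4. The compounds shown leave open whether cyclopropyl in place of propyl on this chain changes inhibition at all.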